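Aryl hydrazone variation against a gastric cancer cell line

The source may report more compounds than this note shows. Statements on the series, on what has been measured and on what is new or still open speak of the compounds shown alone.

Compound 1 `CN(C)CCn1cnnc1-c1cc(Oc2ccc(NC(=O)N/N=C/c3ccc(Cl)cc3Cl)cc2F)ccn1` gives 750 nM in a functional assay on MKN-45 cells (Homo sapiens) for cytotoxicity, read by MTT assay, with a stated time of 72 h; a higher number here means a weaker inhibitor, a lower number a stronger inhibitor; compound 2 `CN(C)CCn1cnnc1-c1cc(Oc2ccc(NC(=O)N/N=C/c3ccc(F)cc3)cc2F)ccn1` gives 1030 nM; compound 3 `CN(C)CCn1cnnc1-c1cc(Oc2ccc(NC(=O)N/N=C/c3cccc(Br)c3)cc2F)ccn1` gives 450 nM.

Compound 3 holds the lowest number of the three; the steps that reach it are a 1.7-fold lower number from compound 1 to compound 3 (0.22 log units; within the scatter) and a 2.3-fold lower number from compound 2 to compound 3 (0.36 log units; beyond the scatter). Compound 4 `CN(C)CCn1cnnc1-c1cc(Oc2ccc(NC(=O)N/N=C/c3cc(Br)c(O)c(Br)c3)cc2F)ccn1` differs from compound 3 by 3,5-dibromo-4-hydroxyphenyl in place of 3-bromophenyl on a carbon with a double bond to nitrogen. Within the data shown here, no measured step matches this change; the three aryl swaps seen so far, a 1.4-fold higher number from compound 1 to compound 2 (0.14 log units; within the scatter), a 1.7-fold lower number from compound 1 to compound 3 (0.22 log units; within the scatter) and a 2.3-fold lower number from compound 2 to compound 3 (0.36 log units; beyond the scatter), all stay small, so only a small step in this assay is expected here, with no clear direction. The expected step is a 1.2-fold higher number from compound 3 to compound 4 (0.09 log units; within the scatter). Compound 4 is estimated at 550 nM, with a range from 250 nM to 1500 nM.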

Compound 4, half-maximal inhibitory concentration: 4320 nM
Estimate against measurement, compound 4: 7.9-fold (0.90 log units) below; measured number above the stated range.
By their numbers in this assay, from the lowest: compounds 3, 1 and 2 (each within the scatter of the next, the first and the last beyond it); then compound 4.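

In this assay, the place on a carbon with a double bond to nitrogen proves able to carry a large loss: 3,5-dibromo-4-hydroxyphenyl gives a 9.6-fold higher number from compound 3 to compound 4 (0.98 log units; beyond the scatter), with a 4.2-fold higher number from compound 2 to compound 4 (0.62 log units; beyond the scatter) and a 5.8-fold higher number from compound 1 to compound 4 (0.76 log units; beyond the scatter). Compound 4 is thus the weakest of the four, with its steps to all three others beyond the scatter. No evidence at hand accounts for this rise.

Going by these compounds, whether the hydroxyl or the two bromines carry the loss stays open: a phenyl with a hydroxyl alone or with two bromines alone would separate them. On these data alone, how an amine or a carboxylic acid on this phenyl would behave is also open.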